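Pentan-3-yl in place of sec-butyl on the double-bonded nitrogen

A few compounds are considered here, and "the series" means these few. Any claim that something is new, unique, unknown or untested is made for them only; others in the source may bear on it.

Measured in a functional assay for inhibition, with Rattus norvegicus as the target; a higher number here means a weaker inhibitor, a lower number a stronger inhibitor:
compound 1 `CCCC/N=c1\c(O)c(O)\c1=N/Cc1ccc(C#N)cc1` gives > 30000 nM, which is a limit of the assay and not a number.
compound 2 `C/N=c1\c(O)c(O)\c1=N/Cc1ccc(C#N)cc1` gives > 30000 nM, again a limit of the assay.
compound 3 `CC[C@H](C)/N=c1\c(O)c(O)\c1=N/Cc1ccc(C#N)cc1` gives 2200 nM.

Among the compounds with values here, compound 3 holds the only number among the three values; the other two sit at the limit of > 30000 nM in this assay, at which 2 of the 3 values shown sit. Compound 4 `CCC(CC)/N=c1\c(O)c(O)\c1=N/Cc1ccc(C#N)cc1` differs from compound 3 by pentan-3-yl in place of sec-butyl on a double-bonded nitrogen. Within the data shown here, two steps bear on this change. The step of an at least 13-fold lower number from compound 1 to compound 3 (1.13 log units; beyond the scatter) and the step of an at least 13-fold lower number from compound 2 to compound 3 (1.13 log units; beyond the scatter) both run toward compound 3 and both are large, so the branched group on the double-bonded nitrogen goes with the lower number, while the step that the two limits leave unreadable from compound 1 to compound 2 between the two unbranched chains cannot be read. Among the measured compounds shown here, compound 4 keeps the branching found in compound 3 and merely extends the chain, and no measured step tests that extension alone. The branching is kept, so for compound 4 the expected step is a 1.5-fold lower number from compound 3 to compound 4 (0.17 log units; within the scatter), within the scatter or slightly toward a lower number. Compound 4 is therefore estimated at 1500 nM in this assay, with a range from 500 nM to 5000 nM.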

Compound 4, half-maximal inhibitory concentration: 1300 nM
Beside the measured number, compound 4's estimate is 1.2-fold (0.06 log units) above it; the measured number falls inside the stated range.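

In this assay, exchanging sec-butyl for pentan-3-yl on the double-bonded nitrogen comes to a 1.7-fold lower number from compound 3 to compound 4 (0.23 log units; within the scatter), so the two groups cannot be told apart here, even though sec-butyl carries a defined stereocentre and pentan-3-yl carries none. The large distance from the unbranched chains now holds for a second branched group, with an at least 23-fold lower number from compound 2 to compound 4 (1.36 log units; beyond the scatter) and an at least 23-fold lower number from compound 1 to compound 4 (1.36 log units; beyond the scatter), so among these four compounds only the two branched groups give a number rather than a limit. Compound 1 and compound 2 both stay at a limit and not at a number: the limit of > 30000 nM in this assay, at which 2 of the 4 values shown sit.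

The step between compound 1 and compound 2 cannot be read, so the compounds shown say nothing about how chain length acts among the unbranched groups. They also leave open whether a cyclopentyl ring, a tert-butyl group or a longer branched chain such as heptan-4-yl on the double-bonded nitrogen would keep, lower or lose the number seen with compound 3 and compound 4.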